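Two methoxy groups on the biaryl tail in place of one

A few compounds are considered here, and "the series" means these few. Any claim that something is new, unique, unknown or untested is made for them only; others in the source may bear on it.

In an assay on isolated protein with Bile acid receptor (Homo sapiens) as the target (a higher number here means that more compound is needed for the effect, a lower number that less compound is needed), three compounds have been measured:
Compound 1 `COC(=O)/C=C/c1cccc(N(Cc2ccc(/C=C/c3scnc3C)cc2)C(=O)C2CCCCC2)c1` gives 227 nM.
Compound 2 `COC(=O)/C=C/c1cccc(N(Cc2ccc(-c3ccc(F)c(F)c3)cc2)C(=O)C2CCCCC2)c1` gives 72 nM.
Compound 3 `COC(=O)/C=C/c1cccc(N(Cc2ccc(-c3ccc(OC)cc3)cc2)C(=O)C2CCCCC2)c1` gives 89 nM.

Compound 3 stands second highest of the three numbers; its nearest neighbour is compound 2, with a 1.2-fold higher number from compound 2 to compound 3 (0.09 log units; within the scatter), and the furthest is compound 1, with a 2.6-fold lower number from compound 1 to compound 3 (0.41 log units; beyond the scatter).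

Compound 4 `COC(=O)/C=C/c1cccc(N(Cc2ccc(-c3c(OC)cccc3OC)cc2)C(=O)C2CCCCC2)c1` differs from compound 3 in one place: 2,6-dimethoxyphenyl in place of 4-methoxyphenyl on an aromatic carbon. The steps that touch this position are a 3.2-fold lower number from compound 1 to compound 2 (0.50 log units; beyond the scatter) and a 2.6-fold lower number from compound 1 to compound 3 (0.41 log units; beyond the scatter), both modest, while a 1.2-fold higher number from compound 2 to compound 3 (0.09 log units; within the scatter) shows two different phenyl groups here giving nearly the same number. For the measured compounds named here, no measured step changes the substitution pattern within this phenyl ring, so the expected step of a 1.5-fold higher number from compound 3 to compound 4 (0.16 log units; within the scatter) is small. For compound 4 the estimate in this assay is 130 nM, within 45 nM to 400 nM.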

Compound 4, half-maximal effective concentration: 77 nM
The estimate for compound 4 lay 1.7-fold (0.23 log units) above the measured number, and the stated range covers the measured number.
By their numbers in this assay, from the lowest: compounds 2, 4 and 3 (each within the scatter of the next); then compound 1.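

For the compounds shown here, the first change of substitution pattern within this phenyl ring left the number within the scatter a 1.2-fold lower number from compound 3 to compound 4 (0.06 log units; within the scatter), so adding a second methoxy group and moving both to the 2,6-dimethoxyphenyl arrangement made no readable difference in this assay. The same holds against the 3,4-difluorophenyl group a 1.1-fold higher number from compound 2 to compound 4 (0.03 log units; within the scatter), while the step away from the 2-(4-methyl-1,3-thiazol-5-yl)ethenyl group remains beyond the scatter a 2.9-fold lower number from compound 1 to compound 4 (0.47 log units; beyond the scatter). No available evidence explains this insensitivity to the substitution pattern. Still open, going by these compounds, is whether an amine or a carboxylic acid on this phenyl ring would give a similar number.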